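The source may report more compounds than this note shows. Statements on the series, on what has been measured and on what is new or still open speak of the compounds shown alone.

Of the compounds shown here, two of the shared core have been measured so far. In a functional assay on THP-1 cells (Homo sapiens) for inhibition (on this read-out lower numbers stand for stronger inhibition and higher numbers for weaker inhibition), compound 1 `O=C1NC(=O)/C(=C/c2ccc(C(=O)NC[C@@H]3C[C@@H](OCc4ccccc4-c4ccccc4)CN3C(=O)c3ccccc3C(=O)c3ccc(F)cc3)cc2)S1` gives 320 nM, the highest of the two numbers. Compound 2 `CC(C)Cc1cccc(-c2ccccc2C(C)C)c1O[C@@H]1C[C@@H](CNC(=O)c2ccc(/C=C3\SC(=O)NC3=O)cc2)N(C(=O)c2ccccc2C(=O)c2ccc(F)cc2)C1` gives 92 nM in this assay, a value that lies beyond the scatter on the lower side of compound 1. Among the measured compounds shown here, no pair of measured compounds differs in only one place, so the next comparison rests on the structural change alone. Compound 3 `O=C1NC(=O)/C(=C/c2ccc(C(=O)NC[C@@H]3C[C@@H](OCc4ccccc4-c4ccccc4)CN3C(=O)c3ccccc3C(=O)c3ccc(F)cc3F)cc2)S1` differs from compound 1 in one place: fluoro in place of hydrogen on an aromatic carbon. The change sits on an aromatic carbon of a six-membered aromatic ring of carbon only, ortho to a large group and meta to a fluoro group; cut one bond further out, it reads 4-fluorophenyl to 2,4-difluorophenyl. With no measured step of this kind in the series, the step of a 1.1-fold lower number from compound 1 to compound 3 (0.06 log units; within the scatter) is expected to stay within the scatter, with no clear direction. Compound 3 is therefore estimated at 280 nM, in a range of 120 nM to 700 nM.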

Compound 3, half-maximal inhibitory concentration: 230 nM
Compound 3: the middle estimate sits 1.2-fold (0.09 log units) above what was measured, and the stated range covers the measured number.
By their numbers in this assay, from the lowest: compound 2; then compounds 3 and 1 (each within the scatter of the next).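

In this assay, fluoro in place of hydrogen on an aromatic carbon, ortho to a large group and meta to a fluoro group, gives a 1.4-fold lower number from compound 1 to compound 3 (0.14 log units; within the scatter), so 4-fluorophenyl and 2,4-difluorophenyl cannot be told apart on this read-out. Among the compounds shown here, this is the first step that differs in one place, and it shows that this position carries a fluoro group with no shift beyond the scatter. No supporting data bear on this result.

Going by these compounds, whether chloro, methoxy or an amine at this position would also stay within the scatter remains open. Also open, on these data alone, is whether the same change to 2,4-difluorophenyl reads the same on the core of compound 2, which carries a different group on the ring oxygen.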